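A few compounds are considered here, and "the series" means these few. Any claim that something is new, unique, unknown or untested is made for them only; others in the source may bear on it.

Measured compounds:
Compound 1, `CN(C)C(=O)c1cc2cnc(Nc3ccc(C(=O)NCCCCN=C=S)cc3)nc2n1C1CCCC1`: in a functional assay on NCI-H1299 cells (Homo sapiens) for inhibition, read by CCK-8 assay, with a stated time of 72 h, tested at 10 uM (a higher number here means a stronger effect of the compound at the concentration tested, a lower number a weaker effect), compound 1 gives 74.2%.
Compound 2, `CN(C)C(=O)c1cc2cnc(Nc3ccc(NC(=O)CCCN=C=S)cc3)nc2n1C1CCCC1`: in this assay compound 2 gives 78.8%.

Among these two numbers compound 2 stands highest, with compound 1 nearest; the step of a number 4.6 percentage points higher from compound 1 to compound 2 (within the scatter) is within the scatter, so the two compounds cannot be ordered. Compound 3, `CN(C)C(=O)c1cc2cnc(Nc3ccc(N=C=S)cc3)nc2n1C1CCCC1`, differs from compound 2 by a group of 3 heavy atoms (1 carbon, 1 nitrogen, 1 sulfur; no ring) in place of a group of 9 heavy atoms (5 carbon, 2 nitrogen, 1 oxygen, 1 sulfur; no ring), on an aromatic carbon. Among the compounds with values here, only the one measured step bears on this change: it exchanged one chain-bearing group for another on the same aromatic carbon and left this assay essentially unchanged, at a number 4.6 percentage points higher from compound 1 to compound 2 (within the scatter). Within the data shown here, the change to compound 3 is larger, since the chain and its amide are removed altogether, and no measured pair shows such a removal. The account therefore expects no step beyond the scatter, with some widening of the range; the step is estimated at a number 8.8 percentage points lower from compound 2 to compound 3 (within the scatter). Compound 3 is estimated at 70%, between 50% and 88%.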

Compound 3, a percentage reported as inhibition, at one concentration (the size of the read-out at that concentration, not a potency): 83.7%
Estimate against measurement, compound 3: 13.7 percentage points below; low and high end bracket the measured number.
By their numbers in this assay, from the lowest: compounds 1, 2 and 3 (each within the scatter of the next).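

In this assay, the group of 3 heavy atoms on this aromatic carbon gives a number 4.9 percentage points higher from compound 2 to compound 3 (within the scatter) when it replaces the group of 9 heavy atoms, and a number 9.5 percentage points higher from compound 1 to compound 3 (within the scatter) when it replaces the group of 10 heavy atoms. The earlier pair only exchanged one chain-bearing group for another, whereas these steps show that the chain and its amide can be absent altogether with no step beyond the scatter, so the three compounds cannot be ordered. Nothing shown here gives a reason for this result.

As far as these compounds go, all three compounds keep the same sulfur-containing end group, so it remains open whether an amine or a carboxylic acid on this aromatic carbon would give a similar number. From the compounds shown here alone, because each read-out comes from one concentration, any difference in potency among the three also remains open.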